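Glycine to alanine in a linker: compound 3 to compound 4

The source may hold more compounds than are shown below. What is called first, only, known or untested is meant among the compounds shown, and "the series" means these compounds.

The measured compounds, with their values in an assay on CHO cells for displacement of a labelled ligand from Gonadotropin-releasing hormone receptor (Homo sapiens); on this read-out higher numbers stand for weaker inhibition and lower numbers for stronger inhibition:
compound 1 `CCNC(=O)Nc1ccc(-c2nc3n(Cc4c(F)cccc4F)cc(C(=O)OCC)c(=O)n3c2CN(CC(=O)N2CCC(C(=O)NCC#Cc3ccccc3)CC2)Cc2ccccc2)cc1` gives 140 nM
compound 2 `CCNC(=O)Nc1ccc(-c2nc3n(Cc4c(F)cccc4F)cc(C(=O)OCC)c(=O)n3c2CN(CC(=O)NCCCC(=O)NCC#Cc2ccccc2)Cc2ccccc2)cc1` gives 580 nM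
compound 3 `CCNC(=O)Nc1ccc(-c2nc3n(Cc4c(F)cccc4F)cc(C(=O)OCC)c(=O)n3c2CN(CC(=O)NCC(=O)NCC#Cc2ccccc2)Cc2ccccc2)cc1` gives 170 nM

Compound 3 stands second highest of the three numbers. Its nearest neighbour is compound 1, whose value in this assay lies within the scatter of that of compound 3, so no order between the two can be read. Compound 2 stands furthest away, with a higher number than compound 3 by a gap beyond the scatter.

Compound 4 `CCNC(=O)Nc1ccc(-c2nc3n(Cc4c(F)cccc4F)cc(C(=O)OCC)c(=O)n3c2CN(CC(=O)N[C@@H](C)C(=O)NCC#Cc2ccccc2)Cc2ccccc2)cc1` differs from compound 3 in one place: methyl in place of hydrogen on a saturated chain carbon bound to an amide-type nitrogen and a carbonyl carbon. Among the measured compounds shown here, no pair among the measured compounds differs in this way, so the data give no measured step of this kind to lean on. With a single carbon entering on a saturated chain carbon bound to an amide-type nitrogen and a carbonyl carbon, the expected step from compound 3 to compound 4 is small, a 1.1-fold higher number from compound 3 to compound 4 (0.02 log units; within the scatter), and is not expected to exceed the scatter in either direction. On that basis compound 4 is estimated at 180 nM, with a range from 80 nM to 400 nM.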

Compound 4, inhibition constant: 1600 nM
Compound 4: middle estimate off by 8.9-fold (0.95 log units), on the low side; measured number above the stated range.
By their numbers in this assay, from the lowest: compounds 1 and 3 (each within the scatter of the next); then compound 2; then compound 4.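

In this assay, methyl in place of hydrogen on a saturated chain carbon bound to an amide-type nitrogen and a carbonyl carbon gives a 9.4-fold higher number from compound 3 to compound 4 (0.97 log units; beyond the scatter). The earlier compounds shown here varied the linker only in other ways, and this step shows that a single added carbon at this position, with no ring, hydrogen-bond donor, hydrogen-bond acceptor or net charge entering, can move the number well beyond the scatter. No measurement shown bears on what lies behind this step.

On these data alone, compound 4 carries one configuration at this carbon, so whether the mirror-image methyl would read the same remains open. Also open, as far as these compounds go, is how an ethyl or a hydroxymethyl on this carbon would read in this assay, and whether the step would hold in the other linkers.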